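This account rests on a few compounds, and the source may have more. Where it says the series, first, only, none or still open, it means among the compounds named here.

Measured compounds:
compound 1 `CC(C)n1nccc1-c1ccccc1NCC1=NCCN1` — 0%
compound 2 `c1ccc(-c2nc[nH]n2)c(NCC2=NCCN2)c1` — 100%
compound 3 `c1ccc(-c2cn[nH]c2)c(NCC2=NCCN2)c1` — 72%

In a functional assay with Alpha-1B adrenergic receptor (Homo sapiens) as the target, read by calcium flux (a lower number here means a smaller maximal response, a higher number a larger maximal response), compound 1 gives 0%, the lowest of the three numbers; compound 3 stands nearest, and compound 2 furthest, both beyond the scatter. Going by the values given here, the one change among the measured set replaces one five-membered heteroaromatic ring by another on the shared core: a number 28 percentage points lower from compound 2 to compound 3 (beyond the scatter).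

Compound 4 `CCCn1nccc1-c1ccccc1NCC1=NCCN1` is not yet measured. It differs from compound 1 in one place: propyl in place of isopropyl on an aromatic nitrogen. The two have the same atoms, joined differently; the group that leaves and the group that enters both sit on an aromatic nitrogen of the five-membered ring.

Among the compounds with values here, no measured step touches the alkyl group on the ring nitrogen; the step from compound 2 to compound 3 concerns the ring itself and does not bear directly on this change. Within the data shown here, compound 1 is the only compound with a substituted ring nitrogen and shows no response at all, whereas compound 2 and compound 3, both with an unsubstituted ring nitrogen, respond strongly. The expectation is that compound 4 keeps a low maximal response, with a step of a number 10 percentage points higher from compound 1 to compound 4 (within the scatter) from compound 1 that stays near the scatter. Compound 4 is estimated at 10%, with a range from 0% to 40%.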

Compound 4, largest response reached (reported as maximal response), in percent of the reference or control that the assay uses: 0%
Compound 4: the middle estimate sits 10 percentage points above what was measured, and the stated range covers the measured number.
By their numbers in this assay, from the lowest: compounds 1 and 4 (each within the scatter of the next); then compound 3; then compound 2.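

Working notes on the alkyl group on the ring nitrogen: in this assay, propyl in place of isopropyl on an aromatic nitrogen gives no change at the digits printed from compound 1 to compound 4 (within the scatter), so at this position the branched and the straight chain read alike. Going by these compounds alone, until now, compound 1 stood alone as the one compound with an alkyl group on this nitrogen, so its reading could have been particular to isopropyl; compound 4, at 0%, shows the same reading with propyl, although a pair that gives no response cannot show whether this change would matter in a compound that does respond. The data at hand offer no explanation for the matching readings.

Open, going by these compounds, is whether a smaller group such as methyl, a longer chain such as butyl, or a chain ending in an amine on this nitrogen would restore any response. Also open is what a hydrogen on this nitrogen would give with the ring of compound 1 otherwise unchanged, as no step shown links compound 1 or compound 4 to a compound that responds.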